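Moving a chlorine on a compound at the assay limit

The source may report more compounds than this note shows. Statements on the series, on what has been measured and on what is new or still open speak of the compounds shown alone.

In an ADME assay on microsomes from liver (Homo sapiens) for metabolic stability (a lower number here means that the compound disappears faster, a higher number that the compound lasts longer), compound 3 `Cn1c(-c2ccc(Cl)cc2)cnc1NC(=O)c1ncc[nH]1` gives > 4.25 h, which is a limit of the assay and not a number. Compound 1 `COc1ccc(-c2cnc(NC(=O)c3ncc[nH]3)n2C)cc1` also stops at a limit, > 4.25 h. These two compounds share (the limit of > 4.25 h in this assay, at which 2 of the 3 values shown sit). Among the compounds with values here, the only measured step between them is a step that the two limits leave unreadable from compound 1 to compound 3, with chloro in place of methoxy on an aromatic carbon. Compound 2 `O=C(Nc1ncc(-c2ccccc2)o1)c1ccc(F)cc1`, which differs from both in more than one place, gives a real number, 0.317 h, but it says little about the change considered here.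

Compound 4 `Cn1c(-c2cccc(Cl)c2)cnc1NC(=O)c1ncc[nH]1` has the same atoms as compound 3, joined differently: 3-chlorophenyl in place of 4-chlorophenyl on an aromatic carbon. The chlorine stays on the phenyl ring, as 3-chlorophenyl in place of 4-chlorophenyl. Within the data shown here, no measured step shows what such a move does, so no step beyond the usual scatter is expected in this assay. The expected step is a step that the limit leaves unreadable from compound 3 to compound 4. For compound 4 the estimated half-life is 4.5 h, with an expected range from 1.5 h to 9 h.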

Compound 4, half-life in the Homo sapiens assay: 3.82 h
Beside the measured number, compound 4's estimate is 1.2-fold (0.07 log units) above it, and the stated range covers the measured number.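

In the Homo sapiens assay the move of the chlorine gives an at least 1.1-fold lower number from compound 3 to compound 4 (0.04 log units; that floor lies within the scatter). What is new is a readable half-life for the 3-chlorophenyl group on the shared core, with no loss beyond the scatter that can be claimed from this pair. In a physicochemical assay for solubility, read by nephelometry, measured as kinetic solubility, at pH 2.0 (on this read-out lower numbers stand for lower solubility and higher numbers for higher solubility), compound 3 gives 50 ug/mL and compound 4 gives 12.5 ug/mL. In the physicochemical assay the same move does lower solubility beyond the scatter: the measured solubility of compound 3, 50 ug/mL, and of compound 4, 12.5 ug/mL, a 4.0-fold lower number (0.60 log units; beyond the scatter)

Going by these compounds, the half-life of compound 3 is known only as a limit, so how far it lies past that limit, and with it the real size of the step, stays open. Also open, on these data alone, is whether a different group on the phenyl ring in place of the chlorine, such as an amine or a carboxylic acid, would keep the half-life and restore the solubility.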